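From Cyano to Ethoxy on the Side Chain

The source may hold more compounds than are shown below. What is called first, only, known or untested is meant among the compounds shown, and "the series" means these compounds.

In a functional assay (trachea) with Cavia porcellus as the target (on this read-out higher numbers stand for an effect only at larger amounts of compound and lower numbers for an effect already at smaller amounts), compound 1 (`CCCn1c(=O)n(CCC(=O)O)c(=O)c2[nH]cnc21`) gives 21200 nM and compound 2 (`CCCn1c(=O)n(C)c(=O)c2c1ncn2CCC#N`) gives 27600 nM in the same range. Compound 2 thus stands level with compound 1, the two numbers lying within the usual scatter of each other. Compound 3 (`CCCn1c(=O)n(C)c(=O)c2c1ncn2CCOCC`) has not yet been measured. It carries ethoxy in place of the cyano of compound 2, on a saturated chain carbon, two bonds along the chain from an aromatic nitrogen (ethoxy in place of cyano on a saturated chain carbon, two bonds along the chain from an aromatic nitrogen). Going by the values given here, no measured pair differs in one place only, so the data give no direct guide to this change. In this assay, the expectation is therefore no shift beyond the scatter, in either direction. The estimated 1.1-fold lower number from compound 2 to compound 3 (0.04 log units; within the scatter) is accordingly small. For compound 3 the expected value is 25000 nM with an estimated range from 8000 nM to 80000 nM in this measurement.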

Compound 3, half-maximal effective concentration: 4600 nM
Compound 3: middle estimate off by 5.4-fold (0.74 log units), on the high side; measured number outside the range, below it.
By their numbers in this assay, from the lowest: compound 3; then compounds 1 and 2 (each within the scatter of the next).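

In this assay, ethoxy in place of cyano on a saturated chain carbon, two bonds along the chain from an aromatic nitrogen, gives a 6.0-fold lower number from compound 2 to compound 3 (0.78 log units; beyond the scatter) and this modest step is the first change in one place among these compounds. It shows that what ends this side chain matters to the read-out, even though one more heavy atom enters than leaves and the count of hydrogen-bond acceptors stays the same. No measurement at hand says why the number moves.

Going by these compounds, whether the step belongs to the oxygen of the ethoxy or to its carbons remains open, since a single pair cannot separate the two. Nor do these compounds show how a methoxy, a longer propoxy or an amine at the same place would read.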